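Hydroxyphenyl for dimethoxyphenyl: expected cytotoxicity of compound 4

The source may report more compounds than this note shows. Statements on the series, on what has been measured and on what is new or still open speak of the compounds shown alone.

The series shares a core carrying an isopropyl amide and an acid-bearing chain, and differs in the group on its terminal ring. Compound 3 `COc1cc(OC)cc(-c2ccc(C(=O)N(Cc3cccc(OCCCCCC(=O)O)c3)C(C)C)cc2)c1` is the starting point here. In an ADME assay on HepG2 cells (Homo sapiens) for cytotoxicity, read by CellTiter-Glo and resazurin assay, with a stated time of 72 h (on this read-out lower numbers stand for an effect already at smaller amounts and higher numbers for an effect only at larger amounts of compound), compound 3 gives > 26000 nM, which is a limit of the assay rather than a number. Compound 1 `CC(C)N(Cc1cccc(OCCCCCC(=O)O)c1)C(=O)c1ccc(-c2cccc(N(C)C)c2)cc1` is another member, and in this assay compound 1 gives > 26000 nM, again a limit. Compound 2 `CC(C)N(Cc1cccc(OCCCCCC(=O)O)c1)C(=O)c1ccc(-c2cccc(-c3ccccc3)c2)cc1` completes the measured set, and in this assay compound 2 gives > 26000 nM, also a limit. Because of the limit of > 26000 nM in this assay, at which 3 of the 3 values shown sit, the steps a step that the two limits leave unreadable from compound 1 to compound 2, a step that the two limits leave unreadable from compound 1 to compound 3 and a step that the two limits leave unreadable from compound 2 to compound 3 cannot be sized; the measured compounds show only that none of them reaches an effect within the tested range.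

Compound 4 `CC(C)N(Cc1cccc(OCCCCCC(=O)O)c1)C(=O)c1ccc(-c2cccc(O)c2)cc1` is the next compound. Its difference from compound 3 is 3-hydroxyphenyl in place of 3,5-dimethoxyphenyl on an aromatic carbon. Within the data shown here, no measured step bears directly on a hydroxyl at this position, and the three measured steps are all unreadable, so the expectation rests on the three limits alone. Compound 4 is therefore expected to show no step beyond the scatter, a step that the limit leaves unreadable from compound 3 to compound 4. Compound 4 is estimated at 30000 nM, with a range from 12000 nM to 100000 nM, most likely again reported as a limit.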

Compound 4, half-maximal effective concentration: > 26000 nM
Compound 4 was reported as a limit; the forecaster's own chance of this, stated with the estimate: 75%; the middle value does not contradict the limit.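

In this assay compound 4 gives > 26000 nM as a limit of the assay. No step among compound 1, compound 2, compound 3 and compound 4 can be read, and the cause is this: the limit of > 26000 nM in this assay, at which 4 of the 4 values shown sit. The compounds shown leave open how far each lies from an effect on these cells.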